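This account rests on a few compounds, and the source may have more. Where it says the series, first, only, none or still open, it means among the compounds named here.

Compound 3 `COc1cc(NC(C)CCCNC(=O)NNC(=O)Nc2ccc(O)cc2)c2ncccc2c1` carries a 4-hydroxyphenyl group on an amide-type nitrogen. In a functional assay on SW-620 cells (Homo sapiens) for inhibition, read by MTT assay, with a stated time of 72 h (on this read-out higher numbers stand for weaker inhibition and lower numbers for stronger inhibition), compound 3 reaches only a limit of the assay , > 100000 nM. Its two measured relatives both give numbers: compound 1 `COc1cc(NC(C)CCCNC(=O)NNC(=O)Nc2ccc(Br)cc2)c2ncccc2c1` gives 17000 nM, and compound 2 `COc1cc(NC(C)CCCNC(=O)NNC(=O)Nc2cccc(C(F)(F)F)c2)c2ncccc2c1` gives 21000 nM. Between those two, a 1.2-fold higher number from compound 1 to compound 2 (0.09 log units; within the scatter). Compound 4 `COc1cc(NC(C)CCCNC(=O)NNC(=O)Nc2cccc(Cl)c2)c2ncccc2c1` has not yet been measured in this assay. It differs from compound 3 in one place: 3-chlorophenyl in place of 4-hydroxyphenyl on an amide-type nitrogen. Two measured steps run in the opposite direction: an at least 5.8-fold higher number from compound 1 to compound 3 (0.76 log units; beyond the scatter) and an at least 4.7-fold higher number from compound 2 to compound 3 (0.67 log units; beyond the scatter). The step from compound 3 to compound 4 thus reverses the kind of change seen in those two steps, so compound 4 is expected to move clearly toward stronger inhibition, by an estimated at least 5.0-fold lower number from compound 3 to compound 4 (0.69 log units; beyond the scatter), landing near the numbers of compound 1 and compound 2 rather than at the limit. Compound 4 is therefore estimated at 20000 nM in this assay, with a range from 8000 nM to 50000 nM.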

Compound 4, half-maximal inhibitory concentration: 25000 nM
For compound 4 the middle estimate is 1.3-fold (0.10 log units) below the measured one; the range from low to high includes it.
By their numbers in this assay, from the lowest: compounds 1, 2 and 4 (each within the scatter of the next). At a limit, above all of these: compound 3.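

In this assay the 3-chlorophenyl group on the amide-type nitrogen gives a number again, an at least 4.0-fold lower number from compound 3 to compound 4 (0.60 log units; beyond the scatter). Compound 3 remains at a limit of the assay: the limit of > 100000 nM in this assay, at which 1 of the 4 values shown sits. Compound 4 lies within the scatter of its other relatives, a 1.2-fold higher number from compound 2 to compound 4 (0.08 log units; within the scatter) and a 1.5-fold higher number from compound 1 to compound 4 (0.17 log units; within the scatter), so this third substituted phenyl group cannot be told apart from the other two, and among these four compounds only the 4-hydroxyphenyl group stands apart.

Going by these compounds, whether a 4-aminophenyl or a 4-carboxyphenyl group would behave like the 4-hydroxyphenyl group or like the other three remains open. The compounds shown also leave open how far compound 3 truly lies from the others, and a 3-hydroxyphenyl group would be needed to tell whether the hydroxy group acts the same from another ring position.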